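Replacing the Carboxy Chain of Compound 2

The source may hold more compounds than are shown below. What is called first, only, known or untested is meant among the compounds shown, and "the series" means these compounds.

In an ADME assay on microsomes from liver (Mus musculus) for metabolic stability, read by LC-MS, using NADPH, with a stated time of 60 min, tested at 1 uM (a higher number here means that the compound lasts longer, a lower number that the compound disappears faster), the measured compounds read as follows:

Compound 1 (`O=S(=O)(c1cccc(C(F)(F)F)c1)N1CCc2ccc(OCc3c(F)cccc3Cl)cc21`) gives 0.0483 h
Compound 2 (`O=C(O)CCCC1Cc2ccc(-c3cc(F)cc(OC(F)F)c3)cc2N1S(=O)(=O)c1cccc(C(F)(F)F)c1`) gives 1.56 h

Compound 2 stands highest of these two (1.56 h), while compound 1 (0.0483 h) lies beyond the scatter below it. These two compounds differ in more than one place, so their gap gives no size for any single change.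

Compound 3 (`O=C(O)C1CCN(C(=O)CC2Cc3ccc(-c4cc(F)cc(OC(F)F)c4)cc3N2S(=O)(=O)c2cccc(C(F)(F)F)c2)CC1`) has not yet been measured. It carries (4-carboxypiperidin-1-yl)carbonyl in place of 2-carboxyethyl on a saturated chain carbon bound to a saturated ring carbon. The rest of compound 2 stays as it is.

Going by the values given here, no measured pair shows what this replacement does in this assay, so the expectation is cautious and takes compound 2 at 1.56 h as its starting point. No step beyond the scatter is expected, with only a slight lean towards a lower number. The estimated step is a 1.1-fold lower number from compound 2 to compound 3 (0.05 log units; within the scatter), and it is expected to stay within the scatter. For compound 3 the estimated half-life is 1.4 h, with an expected range of 0.55 h to 3.5 h.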

Compound 3, half-life: 0.502 h
Compound 3: the middle estimate sits 2.8-fold (0.45 log units) above what was measured; the whole stated range lies above it.
By their numbers in this assay, from the lowest: compound 1; then compound 3; then compound 2.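

In this assay, going by these compounds alone, the replacement gives the first single-place comparison at this saturated chain carbon, a 3.1-fold lower number from compound 2 to compound 3 (0.49 log units; beyond the scatter), so the number does respond to the group carried at this place. The exchange of 2-carboxyethyl for (4-carboxypiperidin-1-yl)carbonyl keeps the count of one hydrogen-bond donor and the absence of a net charge, while it adds a six-membered non-aromatic ring and a further hydrogen-bond acceptor, so the step is not accompanied by a change in those first two counts. Nothing measured here bears on what lies behind this step.

The ring, its nitrogen and the carbonyl all enter together, so the compounds shown do not divide the step among these parts. From the compounds shown here alone, it also stays open whether a piperidine amide without the carboxylic acid, an amine in its place, or a longer chain ending in a carboxylic acid would stay near compound 2 at 1.56 h or fall further.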